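Boronate protease inhibitors: sulfamoyl addition on the aromatic ring

The source may hold more compounds than are shown below. What is called first, only, known or untested is meant among the compounds shown, and "the series" means these compounds.

Measured compounds:
Compound 1, `Cc1cc(-c2ccccc2)ccc1C(=O)N[C@@H](CCCN=C(N)N)B1O[C@@H]2CC3CC(C3(C)C)[C@]2(C)O1`: 4.2 nM
Compound 2, `CC1(C)OB([C@H](CCCN=C(N)N)NC(=O)c2ccccc2)OC1(C)C`: 70 nM

In an assay on isolated protein for inhibition of serine protease 1 (Homo sapiens) (a higher number here means a weaker inhibitor, a lower number a stronger inhibitor), compound 1 gives 4.2 nM, the lower of the two numbers recorded. Compound 2 gives 70 nM in this assay, a gap beyond the scatter, so compound 1 is the stronger inhibitor of the pair. For the measured compounds named here, compound 1 and compound 2 differ in more than one place, so no single step between them can be read.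

Compound 3, `CCN(CC)S(=O)(=O)c1ccccc1-c1ccc(C(=O)N[C@@H](CCCN=C(N)N)B2O[C@@H]3CC4CC(C4(C)C)[C@]3(C)O2)c(C)c1`, is not yet measured. It carries diethylsulfamoyl in place of hydrogen on an aromatic carbon, the place being ortho to a large group. No comparable single change is available among the measured compounds, so the direction is open; the expectation is a step within or near the scatter, from compound 1 to compound 3 estimated as a 1.4-fold lower number from compound 1 to compound 3 (0.15 log units; within the scatter). Compound 3 is expected to give 3 nM in this assay, within 0.7 nM to 15 nM.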

Compound 3, inhibition constant: 0.62 nM
Compound 3: middle estimate off by 4.8-fold (0.68 log units), on the high side; measured number below the stated range.
By their numbers in this assay, from the lowest: compound 3; then compound 1; then compound 2.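

In this assay, the position ortho to a large group on the core of compound 1 takes diethylsulfamoyl in place of hydrogen with a gain in potency: a 6.8-fold lower number from compound 1 to compound 3 (0.83 log units; beyond the scatter) is a step beyond the scatter. This shows that the position tolerates a sizeable group with no ring and no hydrogen-bond donors, and that such a group can lower the number rather than merely being accepted. No measurement here bears on the reason for the gain.

Only one substituent at this position can be read, and steps involving compound 2 cannot be read. As far as these compounds go, whether the gain depends on the sulfonyl unit or on the ethyl chains remains open, and a plain sulfamoyl group, a methylsulfonyl group or a carboxylic acid on the same carbon would help separate the two.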